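Inversion at the alanine centre in a legumain nitrile series

A few compounds are considered here, and "the series" means these few. Any claim that something is new, unique, unknown or untested is made for them only; others in the source may bear on it.

Compound 1 `CC(C)Oc1cccc(-c2ccc(CN([C@H](C)C(=O)N[C@H](C#N)CC(N)=O)S(C)(=O)=O)cc2)c1` gives 5050 nM in an assay on isolated protein for inhibition of legumain (Homo sapiens), with stated times of 2 min and 60 min; a lower number here means a stronger inhibitor, a higher number a weaker inhibitor. Compound 2 `C[C@H](C(=O)N[C@H](C#N)CC(N)=O)N(Cc1ccc(-c2cccc(C(F)(F)F)c2)cc1)S(C)(=O)=O` reaches only a limit, > 10000 nM. Compound 3 `C[C@@H](C(=O)N[C@H](C#N)CC(N)=O)N(Cc1ccc(-c2ccc(F)cc2)cc1)S(C)(=O)=O` gives 1040 nM.

Compound 3 stands lowest of the two numbers shown; its nearest neighbour is compound 1, whose number is higher by a margin beyond the scatter, while compound 2 sits at a limit (the limit of > 10000 nM in this assay, at which 1 of the 3 values shown sits). Compound 4 `C[C@H](C(=O)N[C@H](C#N)CC(N)=O)N(Cc1ccc(-c2ccc(F)cc2)cc1)S(C)(=O)=O` differs from compound 3 in one way: the two compounds have the same atoms and bonds and differ only in configuration as drawn: 1 of 2 stereo elements differ; a stereocentre at a saturated chain carbon is drawn S in compound 3 and R in compound 4.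

Within the data shown here, the only measured step, an at least 1.9-fold higher number from compound 1 to compound 2 (0.29 log units; that floor lies within the scatter), concerns an aromatic substituent and not configuration, so it does not bear on this change. Among the measured compounds shown here, no measured pair isolates the inversion at this centre. Compound 4 is therefore estimated with wide bounds, leaning to a higher number, since compound 1 and compound 2, both weaker than compound 3, each carry a different aryl substituent and so give no clean comparison. The expected step is a 7.7-fold higher number from compound 3 to compound 4 (0.89 log units; beyond the scatter). For compound 4 the estimate in this assay is 8000 nM, within 2000 nM to 40000 nM.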

Compound 4, half-maximal inhibitory concentration: > 10000 nM
Compound 4: no number, only a limit (the forecaster's own chance of this, stated with the estimate: 40%); middle value at least 1.2-fold (0.09 log units) away from the limit.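

In this assay, inverting the stereocentre at the saturated chain carbon from S to R gives an at least 9.6-fold higher number from compound 3 to compound 4 (0.98 log units; beyond the scatter), and this difference rests on that centre alone: the fact that compounds 3 and 4 differ only in the configuration as drawn Compound 4 gives only a limit, as does compound 2, so the step between them cannot be read: the limit of > 10000 nM in this assay, at which 2 of the 4 values shown sit. With the R centre kept, 4-fluorophenyl in place of 3-isopropoxyphenyl gives an at least 1.9-fold higher number from compound 1 to compound 4 (0.29 log units; that floor lies within the scatter), which shows no gain from that aryl change.

As far as these compounds go, whether the S centre would also give lower numbers with 3-isopropoxyphenyl or 3-(trifluoromethyl)phenyl remains open, as does how far compound 4 lies past its limit. Also open, from the compounds shown here alone, is how this position would respond to a longer chain, such as ethyl, or to hydroxymethyl in place of its methyl.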